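Chlorine on a Pendant Phenyl Ring in Two Related Series

The compounds below may be only part of what the source reports. "The series", "measured", "known", "first", "only" and "open" are said of these compounds alone.

Compound 1, with the structure `N#Cc1c(-c2ccccc2)nc(SCC(=O)Nn2c(COc3ccc(Cl)cc3Cl)nc3ccccc3c2=O)[nH]c1=O`, was tested in a functional assay on the whole organism (strain albino) for inhibition, with Rattus norvegicus as the target, read by paw edema, with stated times of 1 h and 2 h, at a dose of 100 mg/kg by the oral route (on this read-out lower numbers stand for less inhibition and higher numbers for more inhibition at the one dose given (going by the name of the read-out)), where compound 1 gives 86%. Compound 2, with the structure `N#Cc1c(-c2ccc(Cl)cc2)nc(SCC(=O)Nn2c(COc3ccc(Cl)cc3Cl)nc3ccccc3c2=O)[nH]c1=O`, differs from compound 1 in one place: chloro in place of hydrogen on an aromatic carbon. In this assay compound 2 gives 64.9%, and the step of a number 21.1 percentage points lower from compound 1 to compound 2 (beyond the scatter) lies beyond the scatter of the method.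

Compound 3, with the structure `N#Cc1c(Nc2ccccc2)nc(SCC(=O)Nn2c(COc3ccc(Cl)cc3Cl)nc3ccccc3c2=O)nc1-c1ccccc1`, carries a different core from compound 1; the difference between the two cores is not broken down here. In this assay compound 3 gives 78.1%, which is within the scatter of the number for compound 1 and beyond the scatter of the number for compound 2.

Compound 4, with the structure `N#Cc1c(Nc2ccc(Cl)cc2)nc(SCC(=O)Nn2c(COc3ccc(Cl)cc3Cl)nc3ccccc3c2=O)nc1-c1ccccc1`, has not yet been measured. It stands to compound 3 as compound 2 stands to compound 1: chloro in place of hydrogen on an aromatic carbon. The place of the change is described in the same words in both pairs, so the two changes are the same change, made on two different cores.

Among the compounds with values here, the only guide to what compound 4 may do is the one measured example of this change. Since the step from compound 1 to compound 2 was a number 21.1 percentage points lower from compound 1 to compound 2 (beyond the scatter), a step of similar direction is expected from compound 3 to compound 4, and the estimate here is a number 16.1 percentage points lower from compound 3 to compound 4 (beyond the scatter), somewhat tempered: the core of compound 3 is different, and a single pair cannot fix the size of such a step. On that basis compound 4 is expected to give about 62% in this assay, most likely between 48% and 76%.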

Compound 4, a percentage reported as inhibition, in the whole organism at one dose (the size of the read-out at that dose, not a potency): 57.9%
Compound 4: middle estimate off by 4.1 percentage points, on the high side; the range from low to high includes it.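

In this assay the change from hydrogen to chloro gave a number 20.2 percentage points lower from compound 3 to compound 4 (beyond the scatter), and set beside the earlier step, it carried over from one core to the other in both direction and size: the same change on two cores in this assay, a number 21.1 percentage points lower (beyond the scatter) from compound 1 to compound 2 and a number 20.2 percentage points lower (beyond the scatter) from compound 3 to compound 4, 0.9 percentage points apart, within the scatter of two such steps

Within these four compounds, then, the change can be read as one step of about the same size, whether it turns a phenyl into a 4-chlorophenyl in compound 2 or an anilino into a (4-chlorophenyl)amino in compound 4. Within the data shown here, this agreement rests on only two pairs at one oral dose, however, and it does not show why the number falls, nor whether a similar step would appear on any other core or at another dose.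

Among the compounds shown, only hydrogen and chloro occupy this place on the ring, so it remains open whether a fluoro, a methyl or a methoxy group there would move the number in the same way. Also open, going by these compounds, is whether a larger change on the same ring, such as an amine or a carboxylic acid, would follow the same course on both cores.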